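Changing the amide aryl group on a nitrobenzofurazan thioether

This account rests on a few compounds, and the source may have more. Where it says the series, first, only, none or still open, it means among the compounds named here.

Three measured compounds share one core and differ only in the aryl group on the amide nitrogen. Compound 1 `O=C(CCC(=O)OCCCCCCSc1ccc([N+](=O)[O-])c2nonc12)Nc1ccccc1F` gives 3030 nM in a functional assay on 143B cells (Homo sapiens) for inhibition, read by MTT assay, with a stated time of 72 h; on this read-out lower numbers stand for stronger inhibition and higher numbers for weaker inhibition. Compound 2 `O=C(CCC(=O)OCCCCCCSc1ccc([N+](=O)[O-])c2nonc12)Nc1ccccc1Cl` gives 2430 nM in this assay, and compound 3 `O=C(CCC(=O)OCCCCCCSc1ccc([N+](=O)[O-])c2nonc12)Nc1ccc(C(F)(F)F)cc1` gives 2100 nM. Compound 3 has the lowest of the three numbers, but the gaps to the others are small: a 1.4-fold lower number from compound 1 to compound 3 (0.16 log units; within the scatter) and a 1.2-fold lower number from compound 2 to compound 3 (0.06 log units; within the scatter), both within the scatter, so the three compounds cannot be separated on these data.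

Compound 4 `COc1ccc(NC(=O)CCC(=O)OCCCCCCSc2ccc([N+](=O)[O-])c3nonc23)cc1OC` is not yet measured. It differs from compound 3 by 3,4-dimethoxyphenyl in place of 4-(trifluoromethyl)phenyl on an amide-type nitrogen. For the measured compounds named here, the steps that bear on this change are the two aryl swaps already seen on the amide nitrogen, from compound 1 to compound 3 and from compound 2 to compound 3, and both stayed within the scatter. With only three points, all on a narrow band, there is no basis for expecting a step beyond the scatter in this assay in either direction.

Compound 4 is therefore estimated at 2500 nM, with a range of 1100 nM to 6000 nM, which corresponds to an expected step of a 1.2-fold higher number from compound 3 to compound 4 (0.08 log units; within the scatter) from compound 3.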

Compound 4, half-maximal inhibitory concentration: 2770 nM
Beside the measured number, compound 4's estimate is 1.1-fold (0.04 log units) below it; measured number inside the range.
By their numbers in this assay, from the lowest: compounds 3, 2, 4 and 1 (each within the scatter of the next).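

Placing 3,4-dimethoxyphenyl on the amide-type nitrogen in place of 4-(trifluoromethyl)phenyl swaps a group with no hydrogen-bond acceptors for one with two, and the outcome in this assay is a 1.3-fold higher number from compound 3 to compound 4 (0.12 log units; within the scatter) despite that difference in what the two groups carry. The comparisons with the halogen-bearing aryl groups agree, with a 1.1-fold higher number from compound 2 to compound 4 (0.06 log units; within the scatter) when 3,4-dimethoxyphenyl replaces 2-chlorophenyl and a 1.1-fold lower number from compound 1 to compound 4 (0.04 log units; within the scatter) when it replaces 2-fluorophenyl, so the four compounds cannot be separated and the flat picture now extends from halogen and trifluoromethyl substituents to two methoxy groups on the aryl ring. No measurement shown gives a reason why the numbers stay together at this position.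

From the compounds shown here alone, it remains open whether a carboxylic acid or an amine on the aryl ring, or a plain alkyl group in place of the aryl ring, would give a step beyond the scatter at this nitrogen. The compounds also leave open how the numbers respond to a shorter or longer chain than the one they all share, or to a change in the shared core itself.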